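The source may hold more compounds than are shown below. What is called first, only, known or untested is meant among the compounds shown, and "the series" means these compounds.

The measured compounds in an ADME assay on HepG2 cells (Homo sapiens) for cytotoxicity, read by luminescence, CellTiter-Glo and ATP content, with a stated time of 72 h; on this read-out lower numbers stand for an effect already at smaller amounts and higher numbers for an effect only at larger amounts of compound:
compound 1, `COc1cccc(CNCCCNc2ccnc3cc(Oc4ccccc4)ccc23)c1O`, giving 6800 nM;
compound 2, `COc1ccccc1Oc1ccc2c(NCCCNCc3ccco3)ccnc2c1`, giving 6500 nM;
compound 3, `COc1cccc(CNCCCNc2ccnc3cc(Oc4cccc(N(C)C)c4)ccc23)c1O`, giving 7300 nM.

Compound 3 stands at the highest of the three numbers, but all three lie within the scatter of one another, so no order among them can be read. Going by the values given here, the only step between compounds that differ in one place is a 1.1-fold higher number from compound 1 to compound 3 (0.03 log units; within the scatter), and it stays within the scatter. Compound 4, `COc1ccccc1Oc1ccc2c(NCCCNCc3cccc(OC)c3O)ccnc2c1`, differs from compound 3 by 2-methoxyphenyl in place of 3-(dimethylamino)phenyl on an oxygen on an aromatic ring. This change sits on an oxygen on an aromatic ring, as did the measured step, which was flat; compound 2 already carries the 2-methoxyphenoxy group that enters here, and its value is indistinguishable from those of compounds 1 and 3. Compound 4 is therefore expected to show a 1.0-fold lower number from compound 3 to compound 4 (0.02 log units; within the scatter), with no change beyond the scatter. Compound 4 is estimated at 7000 nM in this assay, with a range from 3500 nM to 14000 nM.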

Compound 4, half-maximal effective concentration: 11200 nM
Estimate against measurement, compound 4: 1.6-fold (0.20 log units) below; low and high end bracket the measured number.
By their numbers in this assay, from the lowest: compounds 2, 1, 3 and 4 (each within the scatter of the next).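

In this assay the aryl group on the oxygen on an aromatic ring can now be exchanged as a whole, not only substituted with dimethylamino: 2-methoxyphenyl in place of 3-(dimethylamino)phenyl gives a 1.5-fold higher number from compound 3 to compound 4 (0.19 log units; within the scatter) and stays within the scatter. The two other single changes that end at compound 4 also stay within it: 2-hydroxy-3-methoxyphenyl in place of furan-2-yl gives a 1.7-fold higher number from compound 2 to compound 4 (0.24 log units; within the scatter) and methoxy in place of hydrogen gives a 1.6-fold higher number from compound 1 to compound 4 (0.22 log units; within the scatter) so none of the three places shown has yet moved this read-out, and no measurement on hand speaks to a cause.

The compounds shown leave open whether a carboxylic acid on the aryl group would shift the number in this assay beyond the scatter. They also leave open whether a longer chain between the two amine nitrogens would do so.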